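Swapping 1H-benzimidazol-6-yl for (nitrooxy)methyl on the amide

A few compounds are considered here, and "the series" means these few. Any claim that something is new, unique, unknown or untested is made for them only; others in the source may bear on it.

The series keeps one core and varies the group on an amide-type nitrogen, as in compound 1 (`C=C(CC)C(=O)c1ccc(OCC(=O)Nc2ccc(C(=O)O)cn2)c(Cl)c1Cl`), compound 2 (`C=C(CC)C(=O)c1ccc(OCC(=O)Nc2ccc(C(=O)O)cc2)c(Cl)c1Cl`) and compound 3 (`C=C(CC)C(=O)c1ccc(OCC(=O)Nc2ccc3nc[nH]c3c2)c(Cl)c1Cl`). In a functional assay on CLL cells (Homo sapiens) for cytotoxicity, read by MTT assay, with a stated time of 48 h (a lower number here means that less compound is needed, a higher number that more compound is needed for the effect), compound 1 gives 14900 nM, compound 2 gives 5000 nM and compound 3 gives 3200 nM. Compound 3 is not separated from compound 2, with a 1.6-fold lower number from compound 2 to compound 3 (0.19 log units; within the scatter), but stands clear of compound 1, with a 4.7-fold lower number from compound 1 to compound 3 (0.67 log units; beyond the scatter).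

Compound 4 (`C=C(CC)C(=O)c1ccc(OCC(=O)NCO[N+](=O)[O-])c(Cl)c1Cl`) carries (nitrooxy)methyl in place of 1H-benzimidazol-6-yl on an amide-type nitrogen. All measured steps at this nitrogen exchange one ring-bearing group for another, so they give only a scale for a change to a group with no ring. That scale runs from a 1.6-fold lower number from compound 2 to compound 3 (0.19 log units; within the scatter) through a 3.0-fold lower number from compound 1 to compound 2 (0.47 log units; beyond the scatter) to a 4.7-fold lower number from compound 1 to compound 3 (0.67 log units; beyond the scatter). Going by these compounds, no step beyond the scatter is therefore expected in this assay, and the direction remains open. The estimated change is a 1.4-fold higher number from compound 3 to compound 4 (0.15 log units; within the scatter). The expected value for compound 4 is 4500 nM, with an estimated range of 1500 nM to 13000 nM.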

Compound 4, half-maximal effective concentration: 4100 nM
Beside the measured number, compound 4's estimate is 1.1-fold (0.04 log units) above it, within the range that was stated.
By their numbers in this assay, from the lowest: compounds 3, 4 and 2 (each within the scatter of the next); then compound 1.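

In this assay, (nitrooxy)methyl is the only group shown on the amide-type nitrogen with no ring, yet compound 4 is not separated from the ring-bearing compound 3 (a 1.3-fold higher number from compound 3 to compound 4 (0.11 log units; within the scatter)) or compound 2 (a 1.2-fold lower number from compound 2 to compound 4 (0.09 log units; within the scatter)). At this position, a ring is therefore not needed to reach this range of values in the compounds shown, and compound 1 remains apart from the ring-free group (a 3.6-fold lower number from compound 1 to compound 4 (0.56 log units; beyond the scatter)). No supporting measurement bears on why such different groups give values within the scatter of each other.

The compounds shown do not separate the contribution of the nitrooxy group from that of the short chain carrying it. A hydroxymethyl, an aminomethyl or a longer chain ending in a nitrooxy group on this nitrogen would address that question.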